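A few compounds are considered here, and "the series" means these few. Any claim that something is new, unique, unknown or untested is made for them only; others in the source may bear on it.

Measured so far:
compound 1 `C=C(Br)C(=O)Nc1cccc(-c2cn3nc(-c4ccc(C)cc4)sc3n2)c1` — 1700 nM
compound 2 `C=C(Br)C(=O)Nc1cccc(-c2cn3c(-c4ccc(OC)cc4)csc3n2)c1` — 500 nM
compound 3 `Nc1cccc(-c2cn3nc(-c4ccc(F)cc4)sc3n2)c1` — >= 250000 nM (a limit of the assay)

All numbers come from a functional assay on CCRF-CEM cells (Homo sapiens) for inhibition, read by cell counting, with a stated time of 3 days; a lower number here means a stronger inhibitor, a higher number a weaker inhibitor. Compound 1 gives the higher of the two numbers; the number for compound 2 sits lower, beyond the scatter. For compound 3 the assay returns only the limit of >= 250000 nM in this assay, at which 1 of the 3 values shown sits, and no number.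

Compound 4 `C=C(Br)C(=O)Nc1cccc(-c2cn3nc(-c4cccs4)sc3n2)c1` has not yet been measured. It differs from compound 1 in one place:
thiophen-2-yl in place of 4-methylphenyl on an aromatic carbon
Among the compounds with values here, no pair of measured compounds isolates this change, so its size cannot be read from the data. In this assay a step from compound 1 to compound 4 within the scatter is expected, with no clear direction. Compound 4 is estimated at 1500 nM, in the range 500 nM to 5000 nM. That estimate corresponds to a 1.1-fold lower number from compound 1 to compound 4 (0.05 log units; within the scatter).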

Compound 4, half-maximal inhibitory concentration: 410 nM
The estimate for compound 4 lay 3.7-fold (0.56 log units) above the measured number; the measured number lies below the stated range.
By their numbers in this assay, from the lowest: compounds 4 and 2 (each within the scatter of the next); then compound 1. At a limit, above all of these: compound 3.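

In this assay the step of thiophen-2-yl in place of 4-methylphenyl shows a 4.1-fold lower number from compound 1 to compound 4 (0.62 log units; beyond the scatter) on this aromatic carbon next to the ring sulfur. Within the data shown here, the number therefore responds to the group at this position, and a five-membered aromatic ring with one hetero atom is accepted there in place of the six-membered carbon ring; no earlier pair isolated this position.

From the compounds shown here alone, whether an amine, a carboxylic acid or a longer alkyl chain on this carbon would keep the lower number remains open. Nothing measured on these compounds accounts for the step.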